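Liver microsome stability across the pyrrolidine amide series

The source may hold more compounds than are shown below. What is called first, only, known or untested is meant among the compounds shown, and "the series" means these compounds.

Measured so far:
- compound 1 `O=C(O)[C@H]1CC[C@](F)(C(=O)N2CC[C@](c3ccc(C(F)(C(F)(F)F)C(F)(F)F)cc3)(S(=O)(=O)c3ccc(F)cc3)C2)CC1` — "not determined" (no result reported)
- compound 2 `O=C(O)C12CCC(C(=O)N3CC[C@](c4ccc(C(F)(C(F)(F)F)C(F)(F)F)cc4)(S(=O)(=O)c4ccc(F)cc4)C3)(CC1)CC2` — 73%
- compound 3 `O=C(O)C12CCC(C(=O)N3CC[C@](c4ccc(C(F)(C(F)(F)F)C(F)(F)F)cc4)(S(=O)(=O)c4ccc(F)cc4)C3)(CC1)OC2` — 94%

Among the measured compounds shown here, in an ADME assay on microsomes from liver (Mus musculus) for metabolic stability, with a stated time of 10 min (a lower number here means that less of the compound is left, a higher number that more of the compound is left), compound 3 stands highest of the two numbers recorded; its nearest neighbour is compound 2, and the one measured step, a number 21 percentage points higher from compound 2 to compound 3 (beyond the scatter), lies beyond the scatter and is modest in size. Compound 1 carries no result in this assay and cannot be placed.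

Compound 4 `O=C(N1CC[C@](c2ccc(C(F)(C(F)(F)F)C(F)(F)F)cc2)(S(=O)(=O)c2ccc(F)cc2)C1)C1(CO)CCS(=O)(=O)CC1` is the next entry. It differs from compound 3 in a single place: a group of 10 heavy atoms (6 carbon, 3 oxygen, 1 sulfur; one six-membered non-aromatic ring with 1 hetero atom) in place of a group of 11 heavy atoms (8 carbon, 3 oxygen; one six-membered non-aromatic ring of carbon only, one six-membered non-aromatic ring with 1 hetero atom), on a carbonyl carbon. The change sits on the same carbonyl carbon that was altered between compound 2 and compound 3, so that step is the only one that bears on it, and only indirectly, since here the whole acid-bearing ring system is exchanged rather than a single ring atom. Given that the one recorded exchange at this position moved the number by a number 21 percentage points higher from compound 2 to compound 3 (beyond the scatter), and that compound 3 already sits near the top of the read-out, a step of a number 9 percentage points lower from compound 3 to compound 4 (within the scatter) is expected, i.e. nothing clearly beyond the scatter. Compound 4 is therefore estimated at 85%, with a plausible range of 65% to 100%.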

Compound 4, percent of the compound remaining: 31%
The estimate for compound 4 lay 54 percentage points above the measured number, outside the stated range (below it).
By their numbers in this assay, from the lowest: compound 4; then compound 2; then compound 3.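

In this assay, among the compounds shown here, the only earlier step at this place on the carbonyl carbon was a rise, a number 21 percentage points higher from compound 2 to compound 3 (beyond the scatter), and that left open whether the number could fall here at all. The 4-(hydroxymethyl)-1,1-dioxothian-4-yl group now gives the first fall, with a number 63 percentage points lower from compound 3 to compound 4 (beyond the scatter) and a number 42 percentage points lower from compound 2 to compound 4 (beyond the scatter), so the group on this carbonyl carbon can move the number in either direction, and both falls are larger than the earlier rise. With the shared core unchanged, this place alone separates compound 4 from both compound 2 and compound 3, but no measurement shown explains the fall.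

The entering group differs from the group it replaces in several ways at once, with a single ring instead of two, a ring sulfur with its two oxygens, and a hydroxymethyl group, and these three compounds cannot separate those features. A 4-(hydroxymethyl)cyclohexyl group, with carbon only in the ring, would set the hydroxymethyl group apart from the ring sulfur, while an aminomethyl group on the 1,1-dioxothian ring would test the hydroxymethyl group itself.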